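Halogen swap in an isoxazolidine-fused chromone series: compound 3

A few compounds are considered here, and "the series" means these few. Any claim that something is new, unique, unknown or untested is made for them only; others in the source may bear on it.

Measured so far:
compound 1 `O=C1[C@H]2[C@H](ON(c3ccccc3)[C@@H]2c2coc3ccc(F)cc3c2=O)C(=O)N1c1ccccc1` — > 60000 nM
compound 2 `Cc1ccc2occ([C@@H]3[C@H]4C(=O)N(c5ccccc5)C(=O)[C@H]4ON3c3ccccc3)c(=O)c2c1` — > 60000 nM

In a functional assay on Caco-2 cells (Homo sapiens) for inhibition, read by sulforhodamine B assay, with a stated time of 48 h (on this read-out lower numbers stand for stronger inhibition and higher numbers for weaker inhibition), compound 1 reaches only the limit > 60000 nM. In this assay compound 2 likewise stands at the limit > 60000 nM. The step that the two limits leave unreadable from compound 1 to compound 2 therefore cannot be sized, because both values sit at the limit of > 60000 nM in this assay, at which 2 of the 2 values shown sit.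

Compound 3 `O=C1[C@H]2[C@H](ON(c3ccccc3)[C@@H]2c2coc3ccc(Br)cc3c2=O)C(=O)N1c1ccccc1` carries bromo in place of methyl on an aromatic carbon. For the measured compounds named here, the single measured step bears on it only as two limits, so no direction can be read. Compound 3 is estimated at 100000 nM, range 40000 nM to 300000 nM, an expected step that the limit leaves unreadable from compound 2 to compound 3 of no readable size, most likely again a limit.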

Compound 3, half-maximal inhibitory concentration: 20300 nM
The estimate for compound 3 lay 4.9-fold (0.69 log units) above the measured number, and the stated range ends above it.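

In this assay, for the compounds shown here, bromo at this aromatic position gives the first readable number, with an at least 2.9-fold lower number from compound 2 to compound 3 (0.47 log units; beyond the scatter) and with an at least 2.9-fold lower number from compound 1 to compound 3 (0.47 log units; beyond the scatter) as well. Of the three groups shown here, only bromo leaves the limit, so this position can move the read-out on the shared core. Both steps are minimum sizes, and their full size cannot be read, because each starts from a limit: the limit of > 60000 nM in this assay, at which 2 of the 3 values shown sit.

As far as these compounds go, what chloro, an amine or a carboxylic acid would give at this position remains open. From the compounds shown here alone, whether bromo gives a similar step with other groups in place of the phenyl rings also remains open.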